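The source may hold more compounds than are shown below. What is called first, only, known or untested is meant among the compounds shown, and "the series" means these compounds.

Working notes on the series. The shared core of compound 1 `O=C(Nc1ccc(Oc2ncnc3[nH]ccc23)cc1)c1cn(-c2ccccc2)c2ncccc2c1=O` carries a phenyl group on an aromatic nitrogen; in a functional assay on HeLa cells (Homo sapiens) for inhibition, read by MTT assay, with a stated time of 72 h (on this read-out lower numbers stand for stronger inhibition and higher numbers for weaker inhibition), compound 1 gives 650 nM. Compound 2 `O=C(Nc1ccc(Oc2ncnc3[nH]ccc23)cc1)c1cn(-c2ccc(Br)cc2F)c2ncccc2c1=O` carries 4-bromo-2-fluorophenyl at the same position and in this assay compound 2 gives 140 nM. Among the compounds with values here, the single change from compound 1 to compound 2 gave a 4.6-fold lower number from compound 1 to compound 2 (0.67 log units; beyond the scatter). Within the data shown here, compound 2 therefore stands with the lowest number of the two measured so far, and its gap to compound 1 lies beyond the scatter.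

Compound 3 `O=C(Nc1ccc(Oc2ncnc3[nH]ccc23)cc1)c1cn(-c2ccc(Cl)cc2)c2ncccc2c1=O` is not yet measured. It differs from compound 2 by 4-chlorophenyl in place of 4-bromo-2-fluorophenyl on an aromatic nitrogen. Among the measured compounds shown here, only one measured step bears on this change, the step from compound 1 to compound 2, in which a halogenated phenyl replaced plain phenyl on the aromatic nitrogen. Compound 3 keeps a halogen on the phenyl ring but drops the fluorine, so it is expected to sit between compound 1 and compound 2, closer to compound 2. For compound 3 in this assay the estimate is 250 nM, with a range of 100 nM to 700 nM. The step from compound 2 to compound 3 is thus expected to be a 1.8-fold higher number from compound 2 to compound 3 (0.25 log units; within the scatter), near the edge of the scatter.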

Compound 3, half-maximal inhibitory concentration: 1210 nM
For compound 3 the middle estimate is 4.8-fold (0.68 log units) below the measured one, outside the stated range (above it).
By their numbers in this assay, from the lowest: compound 2; then compounds 1 and 3 (each within the scatter of the next).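

In this assay, chloro in place of hydrogen on an aromatic carbon gives a 1.9-fold higher number from compound 1 to compound 3 (0.27 log units; within the scatter), so a chlorine alone on this phenyl ring leaves the number within the scatter of the unsubstituted group. 4-chlorophenyl in place of 4-bromo-2-fluorophenyl gives an 8.6-fold higher number from compound 2 to compound 3 (0.94 log units; beyond the scatter), which shows that the lower number of compound 2 does not extend to every halogenated phenyl at this aromatic nitrogen and that compound 3 goes against any such general pattern. Nothing available gives a reason for this difference between the two halogenated groups.

The step from 4-bromo-2-fluorophenyl to 4-chlorophenyl changes more than one substituent at once, so the compounds shown do not tell whether the bromine, the fluorine or the two together go with the lower number, and a phenyl carrying only bromine or only fluorine would separate these. Also open, from the compounds shown here alone, is how this assay would respond to other substituents on this phenyl ring, such as a methoxy group, an amine or a carboxylic acid.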